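Two Methyl Groups Added on the Ring-Nitrogen Aryl

A few compounds are considered here, and "the series" means these few. Any claim that something is new, unique, unknown or untested is made for them only; others in the source may bear on it.

Three compounds share one core and differ only on an aromatic carbon of it. In a functional assay on A549 cells (Homo sapiens) for inhibition, read by MTT assay, with a stated time of 72 h (a lower number here means a stronger inhibitor, a higher number a weaker inhibitor), compound 1 `Cc1ccc2c(c1)/C(=N/NC(=S)N1CCN(c3ccccc3)CC1)C(=O)N2` gives 9880 nM, compound 2 `COc1ccc2c(c1)/C(=N/NC(=S)N1CCN(c3ccccc3)CC1)C(=O)N2` gives 7520 nM, and compound 3 `O=C1Nc2ccc(Cl)cc2/C1=N/NC(=S)N1CCN(c2ccccc2)CC1` gives 7340 nM. The steps of a 1.3-fold lower number from compound 1 to compound 2 (0.12 log units; within the scatter), a 1.3-fold lower number from compound 1 to compound 3 (0.13 log units; within the scatter) and a 1.0-fold lower number from compound 2 to compound 3 (0.01 log units; within the scatter) all lie within the scatter, so compound 3 has the lowest number without being set apart. Compound 4 `Cc1ccc(N2CCN(C(=S)N/N=C3\C(=O)Nc4ccc(Cl)cc43)CC2)c(C)c1` carries a different change: 2,4-dimethylphenyl in place of phenyl on an amine nitrogen in a ring. None of the measured steps touches that nitrogen, so no shown step bears on it directly. With no guidance, the expected step of a 1.1-fold lower number from compound 3 to compound 4 (0.05 log units; within the scatter) is none beyond the scatter, and compound 4 is estimated at 6500 nM, between 2000 nM and 20000 nM.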

Compound 4, half-maximal inhibitory concentration: 3590 nM
Estimate against measurement, compound 4: 1.8-fold (0.26 log units) above, within the range that was stated.
By their numbers in this assay, from the lowest: compound 4; then compounds 3, 2 and 1 (each within the scatter of the next).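

In this assay, 2,4-dimethylphenyl in place of phenyl gives a 2.0-fold lower number from compound 3 to compound 4 (0.31 log units; beyond the scatter), the only step shown that lies beyond the scatter. The changes on the aromatic carbon of the shared core all stayed within the scatter, whereas this change on the ring amine nitrogen moved the number, though only modestly. Nothing available explains this step.

Going by these compounds, it remains open whether one methyl group alone would give the same step, and how a benzyl group or a chlorophenyl group would behave on that nitrogen.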